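Pyrrole in Place of a Lactam on Two Cores

A few compounds are considered here, and "the series" means these few. Any claim that something is new, unique, unknown or untested is made for them only; others in the source may bear on it.

Compound 1, `Cc1cc(N2CCCC2=O)cn2c(CSCCc3ccccc3)cnc12`, reaches only a limit of > 100 ug/mL in an ADME assay on HEL cells (Homo sapiens) for cytotoxicity, with a stated time of 3 days; on this read-out lower numbers stand for higher toxicity in this test and higher numbers for lower toxicity in this test.
Compound 2, `Cc1cc(-n2cccc2)cn2c(CSCCc3ccccc3)cnc12`, is likewise reported as a limit, >= 4 ug/mL, in this assay.
Compound 3, `Cc1cc(N2CCCC2=O)c2ncc(CSCCc3ccccc3)n2c1`, gives 20 ug/mL in this assay.

The change from compound 1 to compound 2, (1H-pyrrol-1-yl in place of 2-oxopyrrolidin-1-yl on an aromatic carbon), yields a step that the two limits leave unreadable from compound 1 to compound 2 because the limit of > 100 ug/mL in this assay, at which 1 of the 3 values shown sits, on the side of compound 1 and the limit of >= 4 ug/mL in this assay, at which 1 of the 3 values shown sits, on the side of compound 2 are limits rather than numbers. Compound 3 and compound 1 contain the same atoms joined differently; the difference between the two cores is not broken down here. Compound 4, `Cc1cc(-n2cccc2)c2ncc(CSCCc3ccccc3)n2c1`, awaits measurement. It carries the same kind of change as compound 2, (1H-pyrrol-1-yl in place of 2-oxopyrrolidin-1-yl on an aromatic carbon); here the place is ortho to a fused ring, whereas in compound 2 it is para to a fused ring. With the measured step unreadable, the expectation for compound 4 rests on the value of compound 3, 20 ug/mL. The step of a 1.7-fold lower number from compound 3 to compound 4 (0.22 log units; within the scatter) is expected to be small. Compound 4 is expected to give about 12 ug/mL in this assay, between 3 ug/mL and 50 ug/mL.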

Compound 4, minimum cytotoxic concentration: 100 ug/mL
Compound 4: the middle estimate sits 8.3-fold (0.92 log units) below what was measured; measured number outside the range, above it.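

On the core of compound 3, 1H-pyrrol-1-yl in place of 2-oxopyrrolidin-1-yl gives a 5.0-fold higher number from compound 3 to compound 4 (0.70 log units; beyond the scatter) in this assay, so on this core the pyrrole goes with the higher number. The same change from compound 1 to compound 2 cannot be read, as both ends of that step are limits rather than numbers. The series therefore does not show that this step carries over from one core to the other, in size or in direction.

The compounds shown leave open how a piperidine ring or a dimethylamino group at the same place would read in this assay. They also leave open whether a carboxylic acid on the phenyl ring would alter the step.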